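Removing the Chlorine from a Hydrazide Anilide

The source may report more compounds than this note shows. Statements on the series, on what has been measured and on what is new or still open speak of the compounds shown alone.

Compound 2 `O=C(NNC(=O)c1ccncc1)C(=O)Nc1cc(Cl)ccc1O` was examined in an ADME assay on Vero cells (Chlorocebus sabaeus) for cytotoxicity, read by MTT assay, with a stated time of 72 h (on this read-out higher numbers stand for lower toxicity in this test and lower numbers for higher toxicity in this test), where compound 2 gives 1200000 nM. Its companion compound 1 `O=C(NNC(=O)c1ccncc1)C(=O)Nc1ccc(Cl)cc1O` shares the core and the chloro substituent; in this assay compound 1 gives 1170000 nM. Compound 2 thus stands level with compound 1: the gap between the two numbers is within the scatter, so neither can be set apart from the other on this read-out.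

Compound 3 `O=C(NNC(=O)c1ccncc1)C(=O)Nc1ccccc1O` has not yet been measured in this assay. It differs from compound 2 in one place: hydrogen in place of chloro on an aromatic carbon. Within the data shown here, no measured pair in this small set shows what such a change does to the half-maximal cytotoxic concentration. For compound 3 the expected step of a 1.1-fold higher number from compound 2 to compound 3 (0.03 log units; within the scatter) is small, with no direction beyond the scatter. Compound 3 is therefore estimated at 1300000 nM, with a range from 600000 nM to 2800000 nM.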

Compound 3, half-maximal cytotoxic concentration: 1410000 nM
The estimate for compound 3 lay 1.1-fold (0.04 log units) below the measured number, and the stated range covers the measured number.
By their numbers in this assay, from the lowest: compounds 1, 2 and 3 (each within the scatter of the next).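

In this assay, among these compounds, the exchange of chloro for hydrogen gives the first measured steps for this change: (a 1.2-fold higher number from compound 2 to compound 3 (0.07 log units; within the scatter)) and, from the other chloro compound, (a 1.2-fold higher number from compound 1 to compound 3 (0.08 log units; within the scatter)). At the aromatic carbon para to a hydroxy group in compound 2, hydrogen and chloro therefore cannot be told apart on this read-out, and the same holds for the differently placed chloro group of compound 1. Nothing available explains this result.

The compounds shown compare only chloro and hydrogen on this ring, so they leave open whether an amine, a carboxylic acid or a methoxy group at the same carbon would give a step beyond the scatter. They also leave open what happens when the hydroxy group itself is replaced, for instance by a methoxy group.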